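Replacing the 1-Carboxyethenyl Group of Compound 1

The source may report more compounds than this note shows. Statements on the series, on what has been measured and on what is new or still open speak of the compounds shown alone.

Going by the values given here, compound 1 (`C=C(C(=O)O)[C@@H]1C[C@@]2(C)C(=CC1=O)C=C[C@H](OC(=O)CC/C=C/C)[C@@H]2C`) gives 8000 nM in a functional assay on RAW264.7 cells (Mus musculus) for inhibition, read by Griess assay (a higher number here means a weaker inhibitor, a lower number a stronger inhibitor), the lower of the two numbers measured so far and therefore the stronger inhibition. Compound 2 (`C/C=C/CCC(=O)O[C@H]1C=CC2=CC(=O)/C(=C(\C)C(=O)O)C[C@]2(C)[C@H]1C`) gives 45000 nM in this assay, a gap beyond the usual scatter.

The next compound to be tested is compound 3 (`C/C=C/CCC(=O)O[C@H]1C=CC2=CC(=O)[C@H](/C(C=O)=C\OC)C[C@]2(C)[C@H]1C`). It carries 1-formyl-2-methoxyethenyl in place of 1-carboxyethenyl on a saturated ring carbon of the core of compound 1: 1-formyl-2-methoxyethenyl in place of 1-carboxyethenyl on a saturated ring carbon. Among the compounds with values here, no measured pair isolates this change, so the data give no direct size for it.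

Within the data shown here, the only guide is the spread of the two readings. Compound 2, at 45000 nM, lies higher, which leaves compound 1 at the low end of what has been seen. A moderate step towards a higher number, meaning weaker inhibition, is therefore expected in this assay, though it may barely clear the scatter.

For compound 3 the expected value is 15000 nM, with an estimated range of 5000 nM to 50000 nM. This estimate means an expected step of a 1.9-fold higher number from compound 1 to compound 3 (0.27 log units; within the scatter).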

Compound 3, half-maximal inhibitory concentration: 25000 nM
Beside the measured number, compound 3's estimate is 1.7-fold (0.22 log units) below it; low and high end bracket the measured number.
By their numbers in this assay, from the lowest: compound 1; then compounds 3 and 2 (each within the scatter of the next).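

In this assay, going by these compounds alone, the step from 1-carboxyethenyl to 1-formyl-2-methoxyethenyl on a saturated ring carbon gives a 3.1-fold higher number from compound 1 to compound 3 (0.49 log units; beyond the scatter) and is the first size measured for a single change at this place, showing that the number responds to the group carried there. Inhibition does not vanish with the carboxylic acid gone, for compound 3 still gives a measured 25000 nM in this assay, so a free acid in this side group is not needed for a reading in this range. The two groups differ at once in heavy atoms, hydrogen-bond donors and hydrogen-bond acceptors, so this one step cannot assign its size to any of these differences, and nothing at hand explains it.

Going by these compounds, it remains open whether the formyl or the methoxy part of the new group accounts for the step, since neither is seen here on its own. On these data alone, it is equally open how a methyl ester or a primary amide in place of the carboxylic acid of 1-carboxyethenyl would read on the same ring carbon.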